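This account rests on a few compounds, and the source may have more. Where it says the series, first, only, none or still open, it means among the compounds named here.

Measured in a functional assay on LOX IMVI cells (Homo sapiens) for cytotoxicity, read by MTT assay, with a stated time of 24 h; on this read-out lower numbers stand for stronger inhibition and higher numbers for weaker inhibition:
- compound 1 `COc1cc(-c2nc(-c3ccccc3)[nH]c2-c2ccnc(NCCCNS(=O)(=O)c3ccc(Br)cc3)n2)ccc1Cl`: 23700 nM
- compound 2 `O=S(=O)(NCCCNc1nccc(-c2[nH]c(-c3ccccc3)nc2-c2ccc(F)c(O)c2)n1)c1ccc(Br)cc1`: 5660 nM

Of these two, compound 2 has the lower number, 5660 nM, and so the stronger inhibition. Compound 3 `Cc1ccc(S(=O)(=O)NCCCNc2nccc(-c3[nH]c(-c4ccccc4)nc3-c3ccc(F)c(O)c3)n2)cc1` differs from compound 2 in one place: methyl in place of bromo on an aromatic carbon. The bromo of compound 2 gives way to a methyl in compound 3, para to a large group. Going by the values given here, only one measured step is available, a 4.2-fold lower number from compound 1 to compound 2 (0.62 log units; beyond the scatter). Among the compounds with values here, that step changes a different group, so it shows only that a single change can move the number modestly. Within the data shown here, no measured step touches the bromo, and the data therefore give no direction for this swap. The expected result is a 1.1-fold higher number from compound 2 to compound 3 (0.03 log units; within the scatter), an estimated step that stays within the usual scatter. For compound 3 the estimate is 6000 nM, with an expected range of 2500 nM to 14000 nM.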

Compound 3, half-maximal inhibitory concentration: 26300 nM
Beside the measured number, compound 3's estimate is 4.4-fold (0.64 log units) below it, outside the stated range (above it).
By their numbers in this assay, from the lowest: compound 2; then compounds 1 and 3 (each within the scatter of the next).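

In this assay, going by these compounds alone, the change from 4-bromophenyl to 4-methylphenyl gives a 4.6-fold higher number from compound 2 to compound 3 (0.67 log units; beyond the scatter), the first measured step at this position, and inhibition is weaker with methyl. The position is therefore sensitive: replacing one heavy atom with another, with no change in hydrogen-bond donors, acceptors or net charge, is enough to move the number beyond the scatter. No supporting measurement is available to explain why these two groups differ.

From the compounds shown here alone, two groups at one position cannot show what this site prefers, so it remains open whether a trifluoromethyl, a methoxy or an amine there would behave like bromo or like methyl. Going by these compounds, it is also open whether the same swap would have a similar effect alongside the 4-chloro-3-methoxyphenyl group of compound 1.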